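The compounds below may be only part of what the source reports. "The series", "measured", "known", "first", "only" and "open" are said of these compounds alone.

For the measured compounds named here, in a functional assay on A-375 cells (Homo sapiens) for cytotoxicity, read by MTT assay, with a stated time of 72 h (a higher number here means a weaker inhibitor, a lower number a stronger inhibitor), two compounds sharing the same core have numbers so far. Compound 1 `O=C1c2c[n+]([O-])c3ccccc3c2C(=O)c2c1c1ccccc1n2Cc1cn([C@H]2O[C@H](CO)[C@@H](O)[C@H]2O)nn1` gives 340 nM, and compound 2 `O=C1c2c[n+]([O-])c3ccccc3c2C(=O)c2c1c1ccccc1n2Cc1cn(C[C@H](O)CO)nn1` gives 350 nM. Compound 2 therefore stands level with compound 1, as the two values lie within the usual scatter of repeated measurements.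

Compound 3 `CC1(C)OCC(Cn2cc(Cn3c4c(c5ccccc53)C(=O)c3c[n+]([O-])c5ccccc5c3C4=O)nn2)O1` keeps the core of compound 2 and differs only in its side group: 2,2-dimethyl-1,3-dioxolan-4-yl in place of 1,2-dihydroxyethyl on a saturated chain carbon bound to an aromatic nitrogen. In words, a (2,2-dimethyl-1,3-dioxolan-4-yl)methyl group takes the place of the 2,3-dihydroxypropyl group.

Going by the values given here, only one measured step bears on this change: a 1.0-fold higher number from compound 1 to compound 2 (0.01 log units; within the scatter). There, exchanging one side group for another left the number within the scatter. This is thin evidence, since it is a single step and neither measured compound carries the 2,2-dimethyl-1,3-dioxolan-4-yl group. No shift beyond the scatter is expected in this assay, and no direction can be favoured, although the uncertainty is wide.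

The expected step is no change at the digits printed from compound 2 to compound 3 (within the scatter).

For compound 3, the estimated value is 350 nM, within an expected range of 130 nM to 900 nM.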

Compound 3, half-maximal inhibitory concentration: 330 nM
The estimate for compound 3 lay 1.1-fold (0.03 log units) above the measured number; low and high end bracket the measured number.
By their numbers in this assay, from the lowest: compounds 3, 1 and 2 (each within the scatter of the next).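

In this assay, putting 2,2-dimethyl-1,3-dioxolan-4-yl in place of 1,2-dihydroxyethyl on a saturated chain carbon bound to an aromatic nitrogen gives a 1.1-fold lower number from compound 2 to compound 3 (0.03 log units; within the scatter) and stays within the scatter, even though the group that enters has a five-membered non-aromatic ring and 0 hydrogen-bond donors, while the group that leaves has no ring and 2 hydrogen-bond donors. For the compounds shown here, the comparison with the larger sugar-like group gives a 1.0-fold lower number from compound 1 to compound 3 (0.01 log units; within the scatter) and also stays within the scatter, so the earlier compounds, whose side groups both carry free hydroxyl groups, could not show what this one does: in this set of three, a side group without hydrogen-bond donors reads level with those that have them. Nothing available here explains why these numbers stay level.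

Going by these compounds, all three side groups contain oxygen, so it remains open whether a plain butyl chain, an amine or a carboxylic acid at this place would also read level in this assay. The shared core is the same throughout, so these compounds also cannot tell how much of the reading comes from the core itself.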